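The source may hold more compounds than are shown below. What is called first, only, known or untested is meant among the compounds shown, and "the series" means these compounds.

Compounds measured in a functional assay on cells for antagonist activity at prostaglandin D2 receptor 2 (Homo sapiens), read by flow cytometry, with a stated time of 10 min; a higher number here means a weaker inhibitor, a lower number a stronger inhibitor:

Compound 1, `Cc1ccc(S(=O)(=O)NC(C)C)cc1C#Cc1cc(Cl)ccc1OCC(=O)O`, gives 250 nM.
Compound 2, `COCCNS(=O)(=O)c1ccc(C)c(C#Cc2cc(Cl)ccc2OCC(=O)O)c1`, gives 88 nM.
Compound 3, `Cc1ccc(S(=O)(=O)N(C)C)cc1C#Cc1cc(Cl)ccc1OCC(=O)O`, gives 77 nM.

Compound 3 shows the lowest number of the three; its gap to compound 2 lies within the scatter, while its gap to compound 1 lies beyond it. Compound 4, `Cc1ccc(S(=O)(=O)N2CCCCC2C)cc1C#Cc1cc(Cl)ccc1OCC(=O)O`, differs from compound 3 by 2-methylpiperidin-1-yl in place of dimethylamino on a sulfonyl sulfur. Two earlier steps bear on this: a 3.2-fold lower number from compound 1 to compound 3 (0.51 log units; beyond the scatter), and a 1.1-fold lower number from compound 2 to compound 3 (0.06 log units; within the scatter). For the measured compounds named here, both end at the same group that now leaves, and the one step that moved beyond the scatter did so towards compound 3. A larger group on the sulfonyl sulfur is therefore expected to give, if anything, a somewhat higher number in this assay, the step of a 1.4-fold higher number from compound 3 to compound 4 (0.15 log units; within the scatter) being the estimate. Compound 4 is thus expected to show about 110 nM, between 40 nM and 320 nM.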

Compound 4, half-maximal inhibitory concentration: 310 nM
The estimate for compound 4 lay 2.8-fold (0.45 log units) below the measured number, within the range that was stated.
By their numbers in this assay, from the lowest: compounds 3 and 2 (each within the scatter of the next); then compounds 1 and 4 (each within the scatter of the next).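

On the sulfonyl sulfur, a ring could now be compared with open-chain groups, and 2-methylpiperidin-1-yl gave a higher number than either dimethylamino (a 4.0-fold higher number from compound 3 to compound 4 (0.60 log units; beyond the scatter)) or (2-methoxyethyl)amino (a 3.5-fold higher number from compound 2 to compound 4 (0.55 log units; beyond the scatter)). Against isopropylamino it could not be told apart (a 1.2-fold higher number from compound 1 to compound 4 (0.09 log units; within the scatter)), so the number at this position did not simply follow the entering group's heavy-atom count. Nothing measured gives a reason for these steps.

The compounds shown leave open whether the ring or its methyl carries the step, which unsubstituted piperidin-1-yl would test. On these data alone, a smaller ring, such as pyrrolidin-1-yl, also remains open.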